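Amino for Nitro on Two Related Cores

This account rests on a few compounds, and the source may have more. Where it says the series, first, only, none or still open, it means among the compounds named here.

Compound 1 `COc1ccc(OC)c(C(=O)/C=C/c2ccc(OC)c([N+](=O)[O-])c2)c1` and compound 2 `COc1ccc(OC)c(C(=O)/C=C/c2ccc(OC)c(N)c2)c1` share one core, while compound 3 `COc1ccc(OC)c(/C=C/C(=O)c2ccc(OC)c([N+](=O)[O-])c2)c1` and the as yet unmeasured compound 4 `COc1ccc(OC)c(/C=C/C(=O)c2ccc(OC)c(N)c2)c1` share another. Compound 3 and compound 1 are built from the same atoms joined differently, and the difference between the two cores is not broken down here. All values come from a functional assay on B16 cells (Mus musculus) for cytotoxicity, read by MTT assay, with a stated time of 3 days; on this read-out lower numbers stand for stronger inhibition and higher numbers for weaker inhibition. In this assay compound 1 reaches only a limit, > 100000 nM, which is the limit of > 100000 nM in this assay, at which 1 of the 3 values shown sits. Compound 2 gives 2000 nM in this assay. Compound 3 gives 13000 nM in this assay, and so compound 3 stands highest of the two numbers, with compound 2 nearest to it.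

The change from compound 1 to compound 2 is amino in place of nitro on an aromatic carbon. This made an at least 50-fold lower number from compound 1 to compound 2 (1.69 log units; beyond the scatter). The change from compound 3 to compound 4 is amino in place of nitro on an aromatic carbon, the same change carried onto the other core, at a place described in the same words. Among the compounds shown this change occurs twice in all, and only one of the two occurrences has been measured.

For compound 4 a step of a 26-fold lower number from compound 3 to compound 4 (1.41 log units; beyond the scatter) is expected in this assay, resting on the step of an at least 50-fold lower number from compound 1 to compound 2 (1.69 log units; beyond the scatter) seen for the same change. Compound 4 is therefore estimated at 500 nM in this assay, within a range from 100 nM to 3000 nM.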

Compound 4, half-maximal inhibitory concentration: 5600 nM
The estimate for compound 4 lay 11-fold (1.05 log units) below the measured number, outside the stated range (above it).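

In this assay, amino in place of nitro again gives a lower number on the second core, a 2.3-fold lower number from compound 3 to compound 4 (0.37 log units; beyond the scatter), so the direction of the change is the same in both pairs, but its size does not carry from one core to the other: the same change on two cores in this assay, an at least 50-fold lower number (1.69 log units; beyond the scatter) from compound 1 to compound 2 and a 2.3-fold lower number (0.37 log units; beyond the scatter) from compound 3 to compound 4, at least 21-fold (1.33 log units) apart, beyond the scatter of two such steps The earlier step starts from a value that is a limit and not a number, so compound 1 gives that step only a bound: the limit of > 100000 nM in this assay, at which 1 of the 4 values shown sits. Two pairs show that, for these compounds, the measured effect of this change cannot be taken over unaltered from the core of compound 1 to the core of compound 3, but they do not show which difference between the cores goes with the smaller step, nor how the change would fall on any further core.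

The compounds shown leave open whether a hydroxyl group or an acetamide on the same aromatic carbon would give numbers like those of amino or of nitro on either core. They also leave open whether the gap between the two steps would persist if the methoxy group ortho to the changed position gave way to an ethoxy group.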